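The source may report more compounds than this note shows. Statements on the series, on what has been measured and on what is new or still open speak of the compounds shown alone.

Measured in a functional assay on RT-112 cells (Homo sapiens) for antiproliferative activity, read by MTT assay, with a stated time of 72 h; a lower number here means a stronger inhibitor of growth, a higher number a weaker inhibitor of growth:
Compound 1 `COc1cc(Nc2ncnc3c(NC(=O)Nc4ccc(Cl)c(C(F)(F)F)c4)cccc23)cc(OC)c1`: > 20000 nM (a limit)
Compound 2 `COc1cc(Nc2ncnc3c(NC(=O)Nc4ccc(F)cc4C(F)(F)F)cccc23)cc(OC)c1`: 2970 nM
Compound 3 `COc1cc(Nc2ncnc3c(NC(=O)Nc4ccc([N+](=O)[O-])cc4)cccc23)cc(OC)c1`: > 20000 nM (a limit)

Compound 3 gives no number in this assay, only a limit. It sits at the limit of > 20000 nM in this assay, at which 2 of the 3 values shown sit, as compound 1 does. Compound 4 `COc1cc(Nc2ncnc3c(NC(=O)Nc4ccc5c(c4)OCCO5)cccc23)cc(OC)c1` differs from compound 3 in a single place: 2,3-dihydro-1,4-benzodioxin-6-yl in place of 4-nitrophenyl on an amide-type nitrogen. Here 2,3-dihydro-1,4-benzodioxin-6-yl stands in place of 4-nitrophenyl on an amide-type nitrogen.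

Two measured steps at that same place bear on this change: an at least 6.7-fold lower number from compound 1 to compound 2 (0.82 log units; beyond the scatter) and an at least 6.7-fold higher number from compound 2 to compound 3 (0.82 log units; beyond the scatter). Both lie beyond the scatter, and both depend on compound 2. The third step, a step that the two limits leave unreadable from compound 1 to compound 3, adds nothing on size. Going by the values given here, none of these steps involves the group that enters in compound 4, so they show only that a swap at this place can matter.

Compound 2, at 2970 nM, is the only one of the three to give a number. A modest fall from the limit is the most that can be expected in this assay, and compound 4 may well stay at the limit. The estimated change is an at least 1.4-fold lower number from compound 3 to compound 4 (0.15 log units; that floor lies within the scatter). For compound 4 the expected value is 14000 nM, with an estimated range from 3000 nM to 40000 nM.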

Compound 4, concentration for 50% growth inhibition: 2750 nM
Estimate against measurement, compound 4: 5.1-fold (0.71 log units) above, and the stated range ends above it.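

In this assay, the 2,3-dihydro-1,4-benzodioxin-6-yl group gives a second measured value at this amide-type nitrogen, with an at least 7.2-fold lower number from compound 3 to compound 4 (0.86 log units; beyond the scatter) and an at least 7.2-fold lower number from compound 1 to compound 4 (0.86 log units; beyond the scatter). Going by these compounds alone, compound 2 had been the only compound to give a number, and a 1.1-fold lower number from compound 2 to compound 4 (0.03 log units; within the scatter) places a group with no halogen and no trifluoromethyl level with the 4-fluoro-2-(trifluoromethyl)phenyl group, so a trifluoromethyl group is not required for a measured value at this place. The first two steps are floors and not full sizes, as compound 1 and compound 3 each give only a limit: the limit of > 20000 nM in this assay, at which 2 of the 4 values shown sit.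

Going by these compounds, whether the closed non-aromatic ring itself matters stays open, and two separate methoxy groups on the phenyl ring in its place would test this against its two oxygens. Also open, on these data alone, is how a phenyl ring carrying an amine or a carboxylic acid at this nitrogen would read in this assay.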